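Trimming the Sulfonamide from a Triazole-Linked Lactone

The compounds below may be only part of what the source reports. "The series", "measured", "known", "first", "only" and "open" are said of these compounds alone.

The measured compounds: compound 1, `O=C1O[C@H]([C@@H](O)Cn2cc(CNS(=O)(=O)c3ccc(Cl)cc3F)nn2)C(OCc2ccccc2)=C1OCc1ccccc1`, 25500 nM; compound 2, `CCCCCc1ccc(-c2cn(C/C=C3\OC(=O)C(OCc4ccccc4)=C3OCc3ccccc3)nn2)cc1`, > 100000 nM; compound 3, `COc1ccccc1-c1cn(C/C=C2\OC(=O)C(OCc3ccccc3)=C2OCc2ccccc2)nn1`, > 100000 nM.

Among the compounds with values here, in a functional assay on HepG2 cells (Homo sapiens) for antiproliferative activity, read by MTT assay, with a stated time of 72 h (on this read-out lower numbers stand for stronger inhibition and higher numbers for weaker inhibition), compound 1 gives 25500 nM, the only actual number among the three measured compounds. For compound 2 the assay reports only a limit, > 100000 nM. For compound 3 it likewise reports only a limit, > 100000 nM. Within the data shown here, the one measured step, a step that the two limits leave unreadable from compound 2 to compound 3, is therefore unreadable, and it concerns a change at a different position on a different core, so it does not bear on the step from compound 1 to compound 4.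

Compound 4, `CCCCc1cn(C[C@H](O)[C@H]2OC(=O)C(OCc3ccccc3)=C2OCc2ccccc2)nn1`, differs from compound 1 in one place: propyl in place of ((4-chloro-2-fluorophenyl)sulfonyl)amino on a saturated chain carbon bound to an aromatic carbon. Among the measured compounds shown here, no measured pair tracks this change. For the measured compounds named here, the most that can be said is that the two compounds lacking the sulfonamide both sit at the limit of > 100000 nM in this assay, at which 2 of the 3 values shown sit, whereas compound 1 with it is the only one to give a number.

Compound 4 is therefore expected to be weaker than compound 1, with a step of a 2.4-fold higher number from compound 1 to compound 4 (0.37 log units; beyond the scatter), and an estimated value in this assay of 60000 nM, within 20000 nM to 150000 nM.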

Compound 4, half-maximal inhibitory concentration: 32800 nM
Compound 4: middle estimate off by 1.8-fold (0.26 log units), on the high side; the measured number falls inside the stated range.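

In this assay, replacing ((4-chloro-2-fluorophenyl)sulfonyl)amino with propyl on a saturated chain carbon bound to an aromatic carbon gives a 1.3-fold higher number from compound 1 to compound 4 (0.11 log units; within the scatter), so this change cannot be told apart from repeat measurement. The departing group has 12 heavy atoms, a six-membered aromatic ring, 1 hydrogen-bond donor and 2 hydrogen-bond acceptors, while propyl has 3 heavy atoms and no ring, donor or acceptor, so all of these features can go at this position without a readable change in this assay. Compound 4 carries no sulfonamide and still gives an actual number, so a number in this series is not tied to that group, and compound 4 does not join the compounds that remain limits: the limit of > 100000 nM in this assay, at which 2 of the 4 values shown sit.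

What the compounds shown leave open is whether an amine, a carboxylic acid or a chain longer than propyl at this place would shift the number beyond the scatter. They also do not separate the 4-chloro-2-fluorophenyl part of the departing group from its sulfonyl and amino parts, so neither can be judged alone.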